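The source may report more compounds than this note shows. Statements on the series, on what has been measured and on what is new or still open speak of the compounds shown alone.

Of the compounds shown here, three have been measured in a functional assay on T-24 cells (Homo sapiens) for cytotoxicity, read by CCK-8 assay, with a stated time of 24 h; on this read-out higher numbers stand for weaker inhibition and lower numbers for stronger inhibition. Compound 1 `C/C(=C\c1cc(-c2ccc(C)nc2)co1)C(N)=O` gives only a limit in this assay, namely > 50000 nM. Compound 2 `C/C(=C\c1cc(-c2ccc(F)nc2)co1)C(N)=O` likewise gives only a limit in this assay, > 50000 nM. The change from compound 1 to compound 2 is fluoro in place of methyl on an aromatic carbon, and the step it made is a step that the two limits leave unreadable from compound 1 to compound 2, since both ends sit at the same limit of this assay; what is shown is only that both compounds reach (the limit of > 50000 nM in this assay, at which 3 of the 3 values shown sit).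

Compound 3 `C/C(=C\c1nc(-c2ccc(C)cc2)cs1)C(N)=O` rests on a different core from compound 1, and the difference between the two cores is not broken down here. In this assay compound 3 also gives only a limit, > 50000 nM. Compound 4 `C/C(=C\c1nc(-c2ccc(F)cc2)cs1)C(N)=O` has not been measured yet. It is made from compound 3 by fluoro in place of methyl on an aromatic carbon. This is the same kind of change as that from compound 1 to compound 2, but not the same: in compound 1 the methyl sits on a six-membered aromatic ring with one nitrogen, next to the ring nitrogen, whereas in compound 3 it sits on a six-membered aromatic ring of carbon only.

Within the data shown here, with every value shown resting at the limit of > 50000 nM in this assay, at which 3 of the 3 values shown sit, no step of readable size is available, and the expectation for compound 4 is that it too will give no number in this assay. The step from compound 3 to compound 4 is expected to be a step that the limit leaves unreadable from compound 3 to compound 4, resting on the fact that compound 3 already sits at the limit > 50000 nM. Compound 4 is accordingly estimated at 70000 nM in this assay, between 20000 nM and 250000 nM.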

Compound 4, half-maximal inhibitory concentration: > 50000 nM
Compound 4: no number, only a limit; the forecaster's own chance of this, stated with the estimate: 85%; the middle value is on the limit's open side.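

In this assay compound 4 gives only a limit, > 50000 nM. The step from compound 3 to compound 4 therefore cannot be read, and no size can be given for it: the limit of > 50000 nM in this assay, at which 4 of the 4 values shown sit.

The compounds shown leave open whether the change from methyl to fluoro, or the difference between the cores, alters the read-out at all, as none of the four yields a number.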